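Swapping a Sulfonamide for a Phenol on the Shared Core

The source may report more compounds than this note shows. Statements on the series, on what has been measured and on what is new or still open speak of the compounds shown alone.

Measured so far in an assay on isolated protein for binding affinity to Alpha-1D adrenergic receptor (Rattus norvegicus), read by radioligand binding; a higher number here means a weaker inhibitor, a lower number a stronger inhibitor:
compound 1 `CN(c1cccc2c1CCCC2c1c[nH]cn1)S(C)(=O)=O`: 708 nM
compound 2 `CC(C)S(=O)(=O)Nc1cccc2c1CCCC2c1c[nH]cn1`: 2040 nM
compound 3 `CN(C)S(=O)(=O)Nc1cccc2c1CCCC2c1c[nH]cn1`: 1580 nM

Compound 3 sits in the middle of these three numbers. Its step from compound 1 is a 2.2-fold higher number from compound 1 to compound 3 (0.35 log units; beyond the scatter), while its step from compound 2, a 1.3-fold lower number from compound 2 to compound 3 (0.11 log units; within the scatter), is within the scatter, so compound 2 and compound 3 cannot be told apart by these numbers.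

Compound 4 `Oc1cccc2c1CCCC2c1c[nH]cn1` differs from compound 3 in one place: hydroxy in place of (dimethylsulfamoyl)amino on an aromatic carbon. Among the compounds with values here, every measured step so far, a 2.9-fold higher number from compound 1 to compound 2 (0.46 log units; beyond the scatter), a 2.2-fold higher number from compound 1 to compound 3 (0.35 log units; beyond the scatter) and a 1.3-fold lower number from compound 2 to compound 3 (0.11 log units; within the scatter), keeps a sulfonyl group on that carbon and only varies what is attached to it; none of them removes the whole group, so none speaks directly to this change. All three are modest or within the scatter, which hints that this position tolerates variation, but a hydroxy group is a far smaller substituent than any tried. The step from compound 3 to compound 4 is therefore expected to be a 1.6-fold higher number from compound 3 to compound 4 (0.20 log units; within the scatter), with little confidence in its direction. Compound 4 is estimated at 2500 nM, with a range from 600 nM to 10000 nM.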

Compound 4, inhibition constant: 30.9 nM
The estimate for compound 4 lay 81-fold (1.91 log units) above the measured number, and the stated range ends above it.
By their numbers in this assay, from the lowest: compound 4; then compound 1; then compounds 3 and 2 (each within the scatter of the next).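

In this assay the change to hydroxy gives a 51-fold lower number from compound 3 to compound 4 (1.71 log units; beyond the scatter), so this aromatic carbon responds far more strongly to losing the whole (dimethylsulfamoyl)amino group than the earlier swaps among sulfonyl-bearing groups suggested. The comparisons with the other two sulfonyl compounds point the same way, with a 66-fold lower number from compound 2 to compound 4 (1.82 log units; beyond the scatter) and a 23-fold lower number from compound 1 to compound 4 (1.36 log units; beyond the scatter), so the result does not depend on one particular sulfonyl-bearing group. Nothing available here accounts for the size of this change.

These four compounds cannot separate the effect of gaining the hydroxy group from that of losing the larger sulfonyl-bearing group. A methoxy group or a simple amine on the same carbon would help to tell these two readings apart.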